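A few compounds are considered here, and "the series" means these few. Any claim that something is new, unique, unknown or untested is made for them only; others in the source may bear on it.

Three measured members of the series frame the question. Compound 1 `Cc1ccccc1N1CCNC(=O)N1` gives in an assay on RBL-1 cells for inhibition of Polyunsaturated fatty acid 5-lipoxygenase (Rattus norvegicus) (on this read-out lower numbers stand for stronger inhibition and higher numbers for weaker inhibition), a value of 386000 nM. Compound 2 `CCc1cccc(N2CCNC(=O)N2)c1` gives in this assay a value of 13000 nM. Compound 3 `CC1CN(c2cccc(Cl)n2)NC(=O)N1` gives in this assay a value of 3500 nM. Among these three numbers compound 2 stands second highest: compound 3 sits nearest to it with the lower number, and the gap between them lies beyond the usual scatter, while compound 1 sits furthest away with the higher number, again beyond the scatter. Compound 4 `O=C1NCCN(c2cccc(-c3ccsc3)c2)N1` has not yet been measured in this assay. It differs from compound 2 in one place, thiophen-3-yl in place of ethyl on an aromatic carbon of a six-membered aromatic ring of carbon only, meta to a group of 7 heavy atoms. Within the data shown here, no measured pair in the set covers this change, so the size of the step rests on expectation alone. The expected direction is downward, that is toward stronger inhibition, by a step beyond the scatter but not a large one. For compound 4 the expected value in this assay is 4000 nM, with a range from 1000 nM to 20000 nM. The expected step is therefore a 3.3-fold lower number from compound 2 to compound 4 (0.51 log units; beyond the scatter).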

Compound 4, half-maximal inhibitory concentration: 4900 nM
Beside the measured number, compound 4's estimate is 1.2-fold (0.09 log units) below it; the range from low to high includes it.
By their numbers in this assay, from the lowest: compounds 3 and 4 (each within the scatter of the next); then compound 2; then compound 1.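

In this assay, the replacement at this position on the six-membered aromatic ring of carbon only, meta to a group of 7 heavy atoms, gives a 2.7-fold lower number from compound 2 to compound 4 (0.42 log units; beyond the scatter), a modest step toward stronger inhibition that lies beyond the scatter. Among these compounds, the earlier compounds contained no pair differing in one place, so this is the first reading of a single change: here, the position takes thiophen-3-yl, with 5 heavy atoms and a five-membered aromatic ring, in place of the 2-carbon ethyl group without any loss of inhibition. Nothing measured in the set bears on the reason for this step.

A single pair does not separate the contribution of the aromatic ring from that of the sulfur atom or of the larger group as a whole. Still open, as far as these compounds go, is how phenyl, furan-3-yl or a propyl chain would compare on the same aromatic carbon, and whether an amine or a carboxylic acid there would keep, lose or improve the inhibition seen with compound 4.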